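A Single Methoxy Added to an Inactive Compound

The source may hold more compounds than are shown below. What is called first, only, known or untested is meant among the compounds shown, and "the series" means these compounds.

Compound 1 `COc1cc(/C=C/C(=O)/C=C/c2ccccc2)ccc1OCc1cn(CCCOc2cc(=O)oc3ccccc23)nn1` was tested in a functional assay on PC-3 cells (Homo sapiens) for inhibition, read by sulforhodamine B assay, with a stated time of 48 h, tested at 50 uM (on this read-out lower numbers stand for less inhibition of growth and higher numbers for more inhibition of growth at the one concentration tested), where compound 1 is reported as "not active" (no number reported), so no number marks where it stands. Two related compounds give some bearing. Compound 2 `COc1cc(/C=C/C(=O)/C=C/c2cc(OC)c(OC)c(OC)c2)ccc1OCc1cn(CCOc2cc(=O)oc3ccccc23)nn1` reaches 22% in this assay, while compound 3 `COc1cc(/C=C/C(=O)/C=C/c2ccco2)ccc1OCc1cn(CCCCCOc2cc(=O)oc3ccccc23)nn1` is likewise "not active" (no number reported) in this assay. Compound 4 `COc1cccc(/C=C/C(=O)/C=C/c2ccc(OCc3cn(CCCOc4cc(=O)oc5ccccc45)nn3)c(OC)c2)c1` has not yet been measured. It differs from compound 1 in one place: methoxy in place of hydrogen on an aromatic carbon. Because compound 1 gives "not active" (no number reported) and compound 2 shows only 22%, the step to compound 4 in this assay is expected to be small, upward if anything, and likely within the scatter. Compound 4 is therefore estimated at 12%, within 0% to 30%.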

Compound 4, percent growth inhibition at one concentration: "not active" (no number reported)
Compound 4: no number reported; the estimate stays without a comparison.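

In this assay compound 1 gives "not active" (no number reported) and compound 4 gives "not active" (no number reported) with no number for either, so no step can be read between them. On these data alone, whether methoxy in place of hydrogen shifts growth inhibition at all stays open. No measured evidence bears on this result.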